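The source may report more compounds than this note shows. Statements on the series, on what has been measured and on what is new or still open speak of the compounds shown alone.

Compound 1 `Cc1cnc(Nc2ccc(C(C)C)cc2)nc1Nc1nc2ccccc2s1`: > 50000 nM
Compound 2 `COc1cccc(Nc2ncc(C)c(Nc3nc4ccccc4s3)n2)c1`: > 50000 nM
Compound 3 `COc1ccc2nc(Nc3nc(Nc4ccc(S(N)(=O)=O)cc4)ncc3F)sc2c1`: 13000 nM

These three compounds share a core and were tested in a functional assay on HeLa cells (Homo sapiens) for antiproliferative activity, read by MTT assay, with a stated time of 48 h; a lower number here means a stronger inhibitor, a higher number a weaker inhibitor. For compound 1 the value > 50000 nM is a limit of the assay, not a measured number. Compound 2 also sits at a limit, > 50000 nM. Compound 3 alone gives a number, 13000 nM. For the measured compounds named here, the single step between neighbouring compounds, a step that the two limits leave unreadable from compound 1 to compound 2, cannot be read because the limit of > 50000 nM in this assay, at which 2 of the 3 values shown sit, covers both of its ends.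

Compound 4 `Cc1cnc(Nc2ccc(N3CCCCC3)cc2)nc1Nc1nc2ccccc2s1` is not yet measured. It differs from compound 1 by piperidin-1-yl in place of isopropyl on an aromatic carbon. Going by the values given here, no measured step touches this part of the molecule; the only step available changes the other end and is itself unreadable. Among the compounds with values here, what can be said is that compound 1 stands at the limit, so the starting point is weak, and nothing among the measured compounds points to a gain in this assay from this change.

Compound 4 is therefore expected near 50000 nM, with a range from 15000 nM to 150000 nM. The expected step is a number no higher from compound 1 to compound 4 (the limit leaves the size open), which is not beyond the scatter.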

Compound 4, half-maximal inhibitory concentration: 4340 nM
Compound 4: middle estimate off by 12-fold (1.06 log units), on the high side, outside the stated range (below it).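

In this assay, putting piperidin-1-yl in place of isopropyl on this aromatic carbon gives an at least 11-fold lower number from compound 1 to compound 4 (1.06 log units; beyond the scatter). For the compounds shown here, the only earlier step could not be read, so this is the first sign that a change at this place can bring a compound on the shared core off the limit of the assay. The true size of the step stays open because compound 1 is a limit and not a number: the limit of > 50000 nM in this assay, at which 2 of the 4 values shown sit.

The compounds shown do not tell whether the gain goes with the ring, with its nitrogen or with the larger count of heavy atoms in piperidin-1-yl. A dimethylamino group, a morpholine ring or a plain cyclohexyl ring on the same carbon would help to separate these three readings.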